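The source may hold more compounds than are shown below. What is called first, only, known or untested is meant among the compounds shown, and "the series" means these compounds.

Measured in a functional assay on HCT-116 cells (Homo sapiens) for antiproliferative activity, read by MTT assay, with a stated time of 48 h; on this read-out higher numbers stand for weaker inhibition and lower numbers for stronger inhibition:
- Compound 1 `CCCCCCCC(CCO)n1cnc2c(N(C)C)ncnc21`: > 50000 nM (a limit of the assay, not a number)
- Compound 2 `CCCCCCCCCC(CCO)n1cnc2c(N(C)C)ncnc21`: 9810 nM
- Compound 3 `CCCCCCCCCCCC(CCO)n1cnc2c(Cl)ncnc21`: 7590 nM

Compound 3, at 7590 nM, lies within the usual scatter of compound 2, at 9810 nM. Compound 4 `CCCCCCCCCCCC(CCO)n1cnc2c(N(C)C)ncnc21` keeps the chain of compound 3 but has dimethylamino in place of chloro on an aromatic carbon.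

Among the measured compounds shown here, no measured step makes this exchange directly. The nearest evidence is a chain change with dimethylamino in place throughout, which gave an at least 5.0-fold lower number from compound 1 to compound 2 (0.70 log units; beyond the scatter). Compound 4 combines the dimethylamino group of compound 2 with the chain of compound 3, so if that chain trend continues, its number could fall somewhat. The trend rests on a single step, however, and that step starts from a limit, so only a small change is expected in this assay. The expected change is a 1.5-fold lower number from compound 3 to compound 4 (0.18 log units; within the scatter), probably not beyond the scatter. For compound 4 the estimated value is 5000 nM, with an expected range from 1500 nM to 16000 nM.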

Compound 4, half-maximal inhibitory concentration: 12000 nM
The estimate for compound 4 lay 2.4-fold (0.38 log units) below the measured number; the measured number falls inside the stated range.
By their numbers in this assay, from the lowest: compounds 3, 2 and 4 (each within the scatter of the next). At a limit, above all of these: compound 1.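

In this assay, exchanging chloro for dimethylamino on this aromatic carbon gives a 1.6-fold higher number from compound 3 to compound 4 (0.20 log units; within the scatter), so on this chain the read-out does not separate the two groups. Extending the chain with dimethylamino kept gives a 1.2-fold higher number from compound 2 to compound 4 (0.09 log units; within the scatter), so the clear drop seen between the two shorter dimethylamino compounds does not carry on to compound 4. The starting point of an at least 4.1-fold lower number from compound 1 to compound 4 (0.61 log units; beyond the scatter) is a limit and not a number, so that step is only a bound: the limit of > 50000 nM in this assay, at which 1 of the 4 values shown sits.

As far as these compounds go, whether chloro and dimethylamino would also match on a shorter chain remains open. So does whether a simple amino group or a methoxy group on this carbon, or a chain longer than that of compound 4, would move the number beyond the scatter.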